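The compounds below may be only part of what the source reports. "The series", "measured", "known", "first", "only" and "open" are said of these compounds alone.

Compound 1 `COc1cc(C2CC(COCc3cn(Cc4cc(-c5ccc(F)cc5)cnc4Cl)nn3)ON2C=O)cc(OC)c1OC`: 27200 nM
Compound 2 `COc1cc(COCc2cn(Cc3cc(-c4ccc(C)cc4)cnc3Cl)nn2)cc(OC)c1OC`: 28600 nM
Compound 3 `COc1cc(C2=NOC(COCc3cn(Cc4cc(C)cnc4Cl)nn3)C2)cc(OC)c1OC`: 50500 nM

In a functional assay on HeLa cells (Homo sapiens) for cytotoxicity, read by MTT assay, with a stated time of 48 h (on this read-out lower numbers stand for stronger inhibition and higher numbers for weaker inhibition), compound 3 gives 50500 nM, a value within the scatter of both compound 1 and compound 2. Compound 4 `COc1cc(C2=NOC(COCc3cn(Cc4cc(-c5ccccc5)cnc4Cl)nn3)C2)cc(OC)c1OC` has phenyl in place of the methyl of compound 3, on an aromatic carbon of a six-membered aromatic ring with 1 nitrogen, para to a chloro group: phenyl in place of methyl on an aromatic carbon. Going by the values given here, no measured pair isolates this change, so the expectation is loose. Compound 1 at 27200 nM and compound 2 at 28600 nM both carry a substituted phenyl at that place, so a small move towards a lower number, not beyond the scatter, is expected in this assay. The expected step is a 1.6-fold lower number from compound 3 to compound 4 (0.21 log units; within the scatter). For compound 4 the estimated value is 31000 nM, with an expected range of 14000 nM to 65000 nM.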

Compound 4, half-maximal inhibitory concentration: 7300 nM
The estimate for compound 4 lay 4.2-fold (0.63 log units) above the measured number, and the stated range ends above it.
By their numbers in this assay, from the lowest: compound 4; then compounds 1, 2 and 3 (each within the scatter of the next).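

Phenyl in place of methyl on the aromatic carbon para to a chloro group gives, in this assay, a 6.9-fold lower number from compound 3 to compound 4 (0.84 log units; beyond the scatter). This is the only pair shown that differs in one place, and it shows that the number responds to the group at this position, a change the earlier compounds could not isolate. Nothing measured here accounts for the step.

The compounds shown leave open whether an ethyl group, a pyridyl ring or an amine at this carbon would give a similar number. As far as these compounds go, whether the step carries over to another core also remains open.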